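A few compounds are considered here, and "the series" means these few. Any claim that something is new, unique, unknown or untested is made for them only; others in the source may bear on it.

Three measured compounds, one read-out:

Compound 1, `CC(C)(C)OC(=O)NC1CCCN(C(=O)CN2CN(c3ccccc3)C3(CCN(C(=O)c4ccc(C5CCCCC5)cc4)CC3)C2=O)C1`: in an assay on HEK293 cells for displacement of a labelled ligand from NPC1-like intracellular cholesterol transporter 1 (Homo sapiens) (on this read-out lower numbers stand for stronger inhibition and higher numbers for weaker inhibition), compound 1 gives 4400 nM.
Compound 2, `CCOC(=O)C1CCN(C(=O)CN2CN(c3ccccc3)C3(CCN(C(=O)c4ccc(C(C)(C)C)cc4)CC3)C2=O)CC1`: in this assay compound 2 gives 3100 nM.
Compound 3, `COC(=O)CCCNC(=O)CN1CN(c2ccccc2)C2(CCN(C(=O)c3ccc(C4CCCCC4)cc3)CC2)C1=O`: in this assay compound 3 gives 2500 nM.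

Compound 3 carries the lowest of the three numbers, but its gap to compound 2 and its gap to compound 1 both stay within the usual scatter of repeated measurements, so the three compounds cannot be separated on this read-out. No two of them differ in only one place, so no single structural change has yet been measured on its own.

Compound 4, `CS(=O)(=O)N1CCN(C(=O)CN2CN(c3ccccc3)C3(CCN(C(=O)c4ccc(C5CCCCC5)cc4)CC3)C2=O)CC1`, has not yet been measured. It differs from compound 3 in one place: 4-(methylsulfonyl)piperazin-1-yl in place of (3-(methoxycarbonyl)propyl)amino on a carbonyl carbon. The carbonyl that carries this change sits on a saturated chain carbon; the rest of the molecule, including the shared core and the cyclohexylphenyl carbonyl, is unchanged.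

Among the measured compounds shown here, nothing measured so far shows that varying the group at this carbonyl moves the read-out beyond the scatter, since compound 3 at 2500 nM, compound 2 and compound 1 all lie together. The step from compound 3 to compound 4 is therefore expected to be a 1.1-fold higher number from compound 3 to compound 4 (0.05 log units; within the scatter), which means no change beyond the scatter. Compound 4 is estimated at 2800 nM, within a range from 900 nM to 9000 nM.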

Compound 4, half-maximal inhibitory concentration: 6300 nM
Compound 4: the middle estimate sits 2.3-fold (0.35 log units) below what was measured, within the range that was stated.
By their numbers in this assay, from the lowest: compounds 3, 2, 1 and 4 (each within the scatter of the next, the first and the last beyond it).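

Read in this assay the exchange of (3-(methoxycarbonyl)propyl)amino for 4-(methylsulfonyl)piperazin-1-yl gives a 2.5-fold higher number from compound 3 to compound 4 (0.40 log units; beyond the scatter) and stands as the only measured step at this place, modest in size but beyond the scatter. Among the compounds shown here, the earlier compounds could not show that this position responds at all, as no two of them differed in only one place and their numbers lay together. The change replaces an open chain carrying one hydrogen-bond donor with a six-membered non-aromatic ring carrying none, and no measurement given here bears on why the number rises.

As far as these compounds go, a single step cannot separate the ring from the methylsulfonyl group or from the loss of the amide hydrogen, so it remains open where a plain piperazine with a free amine, or an acetyl group in place of the methylsulfonyl, would fall. On the chain side, a carboxylic acid in place of the methyl ester or a longer chain could show whether the open chain tolerates variation, and the same exchange with the tert-butylphenyl carbonyl would show whether the step carries over.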